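The source may report more compounds than this note shows. Statements on the series, on what has been measured and on what is new or still open speak of the compounds shown alone.

Measured so far in a functional assay on the whole organism for agonist activity, with Mus musculus as the target; a lower number here means that less compound is needed, a higher number that more compound is needed for the effect:
compound 1 `COC(=O)N(C)CC#CCn1cncc1C` gives > 100 mg/kg
compound 2 `COC(=O)N(C)C(C)C#CCn1cncc1C` gives > 100 mg/kg

Compound 1 has the reading > 100 mg/kg, which is a limit of the assay and not a number. Compound 2 has the reading > 100 mg/kg, which is likewise only a limit. Going by the values given here, the series so far rests on the limit of > 100 mg/kg in this assay, at which 2 of the 2 values shown sit, and on nothing finer.

Compound 3 `CCOC(=O)N(C)CC#CCn1cncc1C` differs from compound 1 by methyl in place of hydrogen on a saturated chain carbon bound to an oxygen next to a carbonyl group, which turns methoxycarbonyl into ethoxycarbonyl. Among the compounds with values here, the only measured step, a step that the two limits leave unreadable from compound 1 to compound 2, puts a methyl at another place and gives no size to carry over. No shift beyond the usual scatter is therefore expected in this assay, in either direction. The expected change is a step that the limit leaves unreadable from compound 1 to compound 3 and another limit reading is the likeliest outcome. For compound 3 the estimated value is 130 mg/kg within an expected range from 50 mg/kg to 300 mg/kg as a rough guide only.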

Compound 3, dose for half-maximal effect: > 100 mg/kg
Compound 3: a limit, no number (the forecaster's own chance of this, stated with the estimate: 75%); the middle value lies beyond the limit too.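

No step can be read from compound 1 to compound 3, since both readings are limits and not numbers: the limit of > 100 mg/kg in this assay, at which 3 of the 3 values shown sit.

The compounds shown leave open what dose gives the half-maximal effect for any of them, and whether either methyl in place of hydrogen changes that dose.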